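The compounds below may be only part of what the source reports. "The series", "measured", "known", "first", "only" and "open" are said of these compounds alone.

Measured so far in a functional assay (strain AB) with Danio rerio as the target, read by microscopy, with a stated time of 1 h; on this read-out lower numbers stand for an effect already at smaller amounts and higher numbers for an effect only at larger amounts of compound:
- Compound 1 `CCN1CCc2c(sc(NC(=O)Nc3ccc(Cl)cc3)c2C(=O)c2nc(C)no2)C1`: > 25000 nM (a limit)
- Compound 2 `CCN1CCc2c(sc(NC(=O)Nc3ccc(Cl)cc3)c2C(=O)N2CCOCC2)C1`: > 25000 nM (a limit)

Compound 2 stands at > 25000 nM, which is a limit and not a number. Nothing shown so far lies off (the limit of > 25000 nM in this assay, at which 2 of the 2 values shown sit). Compound 3 `CCN1CCc2c(sc(NC(=O)Nc3ccc(Cl)cc3)c2C(=O)NCCO)C1` carries (2-hydroxyethyl)amino in place of morpholin-4-yl on a carbonyl carbon. Within the data shown here, the one measured step that bears on this change is a step that the two limits leave unreadable from compound 1 to compound 2, which also falls on a carbonyl carbon. It offers no size to carry over and no direction, so no step beyond the scatter is expected in this assay, and a further limit is the likeliest report. The expected step is a number no higher from compound 2 to compound 3 (the limit leaves the size open). The estimate for compound 3 is 25000 nM, with an expected range from 8000 nM to 60000 nM.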

Compound 3, half-maximal effective concentration: 9400 nM
For compound 3 the middle estimate is 2.7-fold (0.42 log units) above the measured one; the range from low to high includes it.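

Of the groups shown on the carbonyl carbon, (2-hydroxyethyl)amino is the first to give a number rather than a limit in this assay, with an at least 2.6-fold lower number from compound 2 to compound 3 (0.42 log units; beyond the scatter) and an at least 2.6-fold lower number from compound 1 to compound 3 (0.42 log units; beyond the scatter). This shows that the read-out at this place can respond to a change of group, which the earlier pair could not show. The step between compound 1 and compound 2 cannot be read, and their values remain limits: the limit of > 25000 nM in this assay, at which 2 of the 3 values shown sit.

The compounds shown leave open whether the step goes with the hydroxyl group, the amide hydrogen or the loss of the morpholine ring. Ethylamino, (2-methoxyethyl)amino or a longer chain such as (3-hydroxypropyl)amino on the same carbonyl carbon would bear on that question.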